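Chlorophenyl swap on the spiro-free notes: compound 2 to compound 3

The source may report more compounds than this note shows. Statements on the series, on what has been measured and on what is new or still open speak of the compounds shown alone.

Correction to the title above; the notes in full:

Moving the chloro: 2-chlorophenyl to 4-chlorophenyl

In a functional assay on MDA-MB-231 cells (Homo sapiens) for antiproliferative activity, read by MTT assay, with a stated time of 72 h (a lower number here means a stronger inhibitor, a higher number a weaker inhibitor), compound 1 `NC1=NC2(CCSCC2)N(OCCCOc2cccc(Cl)c2Cl)C(N)=N1` gives 1 nM and compound 2 `NC1=NC2(CCSCC2)N(OCCCOc2ccccc2Cl)C(N)=N1` gives 80 nM, the higher of the two numbers. Compound 3 `NC1=NC2(CCSCC2)N(OCCCOc2ccc(Cl)cc2)C(N)=N1` carries 4-chlorophenyl in place of 2-chlorophenyl on an oxygen on a saturated carbon. For the measured compounds named here, the only measured step, an 80-fold higher number from compound 1 to compound 2 (1.90 log units; beyond the scatter), is large, but it removes a chloro, whereas compound 3 keeps the same atoms joined differently. Going by the values given here, no measured step moves a chloro, so the direction stays open and the expected 1.3-fold lower number from compound 2 to compound 3 (0.12 log units; within the scatter) is none beyond the scatter. For compound 3 the estimated value is 60 nM, with an expected range of 8 nM to 400 nM.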

Compound 3, half-maximal inhibitory concentration: 350 nM
Beside the measured number, compound 3's estimate is 5.8-fold (0.77 log units) below it; the measured number falls inside the stated range.
By their numbers in this assay, from the lowest: compound 1; then compound 2; then compound 3.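

Within this assay, the atoms stay the same and the change of 2-chlorophenyl to 4-chlorophenyl alone gives a 4.4-fold higher number from compound 2 to compound 3 (0.64 log units; beyond the scatter), so a chloro's place on the ring affects the number and not only its presence. Replacing 2,3-dichlorophenyl with 4-chlorophenyl gives a 350-fold higher number from compound 1 to compound 3 (2.54 log units; beyond the scatter), a change that both removes and moves a chloro. Nothing available explains either step. As far as these compounds go, whether 3-chlorophenyl or unsubstituted phenyl would fit this order remains open, as does whether it would hold with a longer chain to the oxygen.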